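The compounds below may be only part of what the source reports. "The series", "measured", "known", "first", "only" and "open" are said of these compounds alone.

Measured compounds:
- compound 1 `CC(C)[C@H](NC(=O)COc1cccc2ccccc12)C(=O)N[C@@H](CC(=O)O)C(=O)COC(=O)c1c(Cl)cccc1Cl`: in a functional assay on Jurkat cells (Homo sapiens) (on this read-out lower numbers stand for stronger inhibition and higher numbers for weaker inhibition), compound 1 gives 10600 nM
- compound 2 `CC(C)[C@H](NC(=O)COc1cccc2ccccc12)C(=O)N[C@@H](CC(=O)O)C(=O)COc1ccccc1C(F)(F)F`: compound 2 sits at the assay limit, > 100000 nM
- compound 3 `CC(C)[C@H](NC(=O)COc1cccc2ccccc12)C(=O)N[C@@H](CC(=O)O)C(=O)COc1cccc(C(F)(F)F)c1`: compound 3 likewise sits at the assay limit, > 100000 nM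

Going by the values given here, compound 1 is the only compound of the three with a number in this assay; the other two values are limits, (the limit of > 100000 nM in this assay, at which 2 of the 3 values shown sit). Both steps away from compound 1 move in the same direction: an at least 9.4-fold higher number from compound 1 to compound 2 (0.97 log units; beyond the scatter) and an at least 9.4-fold higher number from compound 1 to compound 3 (0.97 log units; beyond the scatter). Between the two limits a step that the two limits leave unreadable from compound 2 to compound 3.

Compound 4 `CC(C)[C@H](NC(=O)COc1cccc2ccccc12)C(=O)N[C@@H](CC(=O)O)C(=O)COc1ccc(OC(F)(F)F)cc1` is not yet measured. It differs from compound 1 as follows: 4-(trifluoromethoxy)phenyl in place of (2,6-dichlorophenyl)carbonyl on an oxygen on a saturated carbon. As in the steps to compound 2 and compound 3, the (2,6-dichlorophenyl)carbonyl leaves and an aryl group enters on the same oxygen on a saturated carbon, so the two measured steps bear directly on it. Both were large losses in this assay that ended at the limit. A loss of comparable size is therefore expected, a 9.4-fold higher number from compound 1 to compound 4 (0.97 log units; beyond the scatter), with a real chance that only a limit is reported. The expected value for compound 4 is 100000 nM, within 30000 nM to 300000 nM.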

Compound 4, half-maximal inhibitory concentration: 29100 nM
For compound 4 the middle estimate is 3.4-fold (0.54 log units) above the measured one; the measured number lies below the stated range.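

In this assay, an aryl group on this oxygen on a saturated carbon need not end at the limit: 4-(trifluoromethoxy)phenyl in place of (2,6-dichlorophenyl)carbonyl still gives a readable number, with a 2.7-fold higher number from compound 1 to compound 4 (0.44 log units; beyond the scatter). The aryl groups are therefore not interchangeable at this place, as shown by an at least 3.4-fold lower number from compound 3 to compound 4 (0.53 log units; beyond the scatter) and by an at least 3.4-fold lower number from compound 2 to compound 4 (0.53 log units; beyond the scatter). The values of compound 2 and compound 3 are limits and not numbers: the limit of > 100000 nM in this assay, at which 2 of the 4 values shown sit.

From the compounds shown here alone, it remains open whether a 4-(trifluoromethyl)phenyl group on the same oxygen would also give a readable number, which would separate the effect of trifluoromethoxy from that of trifluoromethyl. Also open, going by these compounds, is how a plain benzoyl group, without the two chlorines, would compare with the (2,6-dichlorophenyl)carbonyl.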